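This account rests on a few compounds, and the source may have more. Where it says the series, first, only, none or still open, it means among the compounds named here.

Measured compounds:
Compound 1 `CCCCNc1nc(-c2ccccc2)nc2c1nnn2Cc1ccccc1C(F)(F)F`: in an assay on isolated protein for binding affinity to adenosine receptor A1 (Bos taurus) (on this read-out lower numbers stand for stronger inhibition and higher numbers for weaker inhibition), compound 1 gives 6500000 nM.
Compound 2 `CCCCNc1nc(-c2ccccc2)nc2c1nnn2Cc1ccccc1F`: in this assay compound 2 gives 4300000 nM.

Within the data shown here, compound 2 and compound 1 give numbers within the scatter of each other; the only measured step, a 1.5-fold lower number from compound 1 to compound 2 (0.18 log units; within the scatter), is itself within the scatter. Compound 3 `OCCCNc1nc(-c2ccccc2)nc2c1nnn2Cc1ccccc1F` differs from compound 2 by hydroxy in place of methyl on a saturated chain carbon, three bonds along the chain from a nitrogen on an aromatic ring. Among the measured compounds shown here, that change sits on the saturated chain, whereas the measured step concerns a substituent on an aromatic carbon, so no measured step bears on it. With nothing to indicate a shift in this assay, compound 3 is expected to show no step beyond the scatter, a 1.1-fold lower number from compound 2 to compound 3 (0.03 log units; within the scatter). The estimate for compound 3 is 4000000 nM, with a range from 1000000 nM to 16000000 nM.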

Compound 3, inhibition constant: 3700000 nM
Compound 3: middle estimate off by 1.1-fold (0.03 log units), on the high side; measured number inside the range.
By their numbers in this assay, from the lowest: compounds 3, 2 and 1 (each within the scatter of the next).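

Among these compounds, this is the first reading on the saturated chain: butyl to 3-hydroxypropyl gives a 1.2-fold lower number from compound 2 to compound 3 (0.07 log units; within the scatter) in this assay. At this position, a change that brings in a hydrogen-bond donor and a hydrogen-bond acceptor therefore gives no step beyond the scatter. No available evidence bears on this result.

Still open, as far as these compounds go, is whether an amine or a carboxylic acid in place of the hydroxy, or a longer chain, would give a step beyond the scatter. Hydroxy at other places along the chain also remains open.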